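The source may report more compounds than this note shows. Statements on the series, on what has been measured and on what is new or still open speak of the compounds shown alone.

Measured compounds in an ADME assay on MT4 cells (Homo sapiens) for cytotoxicity, read by MTT assay, with a stated time of 96 h; on this read-out lower numbers stand for higher toxicity in this test and higher numbers for lower toxicity in this test:
- compound 1 `C/C(=N\O)c1ccc2[nH]c(-c3ccccc3)nc2c1`: "not determined" (no result reported)
- compound 2 `C/C(=N\O)c1ccc2[nH]c(-c3ccc(Cl)cc3)nc2c1`: 20000 nM
- compound 3 `C/C(=N\O)c1ccc2[nH]c(-c3ccc(C(F)(F)F)cc3)nc2c1`: "not determined" (no result reported)

Compound 1 stands without a number in this assay; compound 3 likewise has none, so within the shared core only compound 2 gives a value, 20000 nM. For the measured compounds named here, no step between two measured compounds is available, and nothing ties compound 1 to compound 2 by a measured difference.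

Compound 4 `C/C(=N\NC(N)=S)c1ccc2[nH]c(-c3ccccc3)nc2c1` differs from compound 1 by a group of 4 heavy atoms (1 carbon, 2 nitrogen, 1 sulfur; no ring) in place of one oxygen atom, on a double-bonded nitrogen, on the double-bonded nitrogen whose other neighbour is a carbon with a double bond to nitrogen. With no anchor for compound 1, the expectation for compound 4 rests on compound 2 alone; a shift toward somewhat higher toxicity in this assay, modest and possibly within the scatter, is expected. Compound 4 is estimated at 10000 nM, between 2000 nM and 50000 nM.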

Compound 4, half-maximal cytotoxic concentration: >= 100000 nM
Compound 4: no number, only a limit (the forecaster's own chance of this, stated with the estimate: 25%); middle value at least 10-fold (1.00 log units) away from the limit.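

No step can be read between compound 1 and compound 4. In this assay compound 4 gives only a limit, >= 100000 nM, not a number. On these data alone, what replacing hydroxy on the shared core does to cytotoxicity stays open.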